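Anilinoquinazoline series: boron substituent exchange at compound 3

This account rests on a few compounds, and the source may have more. Where it says the series, first, only, none or still open, it means among the compounds named here.

Two anilinoquinazolines have been run in an assay on isolated protein for inhibition of vascular endothelial growth factor receptor 1 (Homo sapiens), read by ELISA, with a stated time of 20 min, tested at 1 uM (on this read-out lower numbers stand for less inhibition and higher numbers for more inhibition at the one concentration tested (going by the name of the read-out)), so far. Compound 1 `OB(O)c1ccc2ncnc(Nc3ccc(F)c(Cl)c3)c2c1` gives "not active" (no number reported), with no number reported. Compound 2 `OB(O)c1ccc2ncnc(Nc3cccc(Cl)c3)c2c1` gives 7% in this assay, which is the only number shown for the series; compound 1 stands beside it without a single number, so no ordering between the two can be stated.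

The next compound, compound 3 `CC1(C)OB(c2ccc3ncnc(Nc4cccc(Cl)c4)c3c2)OC1(C)C`, differs from compound 2 by a group of 9 heavy atoms (6 carbon, 1 boron, 2 oxygen; one five-membered non-aromatic ring with 3 hetero atoms) in place of a group of 3 heavy atoms (1 boron, 2 oxygen; no ring), on an aromatic carbon. The hydrogen-bond donors of the leaving group are lost, the count of acceptors is unchanged, and the place on the shared core is the same. Among the measured compounds shown here, no measured pair tells what such an exchange does in this assay, and the change itself offers no basis for a move in either direction.

The step of a number 1 percentage points higher from compound 2 to compound 3 (within the scatter) is therefore estimated to be none beyond the scatter. Compound 3 is expected to give 8%, with a range of 0% to 25%.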

Compound 3, a percentage reported as inhibition, at one concentration (the size of the read-out at that concentration, not a potency): 12%
Beside the measured number, compound 3's estimate is 4 percentage points below it; the measured number falls inside the stated range.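

At this aromatic carbon the series now has a first readable exchange: in this assay, a group of 9 heavy atoms with a five-membered non-aromatic ring, in place of a group of 3 heavy atoms with no ring, gives a number 5 percentage points higher from compound 2 to compound 3 (within the scatter). Among the compounds shown here, the larger group and the loss of the 2 hydrogen-bond donors of the leaving group therefore come with no step beyond the scatter at this position, which is something the earlier compounds could not show, as no measured pair existed before. No measurement on hand offers an explanation for this result.

What the compounds shown leave open is whether any other group at this aromatic carbon, such as a carboxylic acid or an amine in place of the two boron-containing groups, would give a step beyond the scatter in this assay. On these data alone, the step involving compound 1 cannot be read, since that compound has no number, so what a fluorine on the other aromatic ring does also stays open.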